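Series notes: 2-hydroxy-3-methylbenzyl in place of 4-methylbenzyl

The compounds below may be only part of what the source reports. "The series", "measured", "known", "first", "only" and "open" are said of these compounds alone.

Compound 1 `Cc1ccc(CNc2ncnc3c2ncn3[C@@H]2O[C@H](CO)[C@@H](O)[C@H]2O)cc1` is the reference point of this set. In a functional assay on CCRF-CEM cells (Homo sapiens) for antiproliferative activity, with a stated time of 72 h (on this read-out lower numbers stand for stronger inhibition and higher numbers for weaker inhibition), compound 1 gives only a limit, > 166000 nM, so no number is available for it. Compound 2 `COc1cc(O)cc(OC)c1CNc1ncnc2c1ncn2[C@@H]1O[C@H](CO)[C@@H](O)[C@H]1O` carries another group of the same kind; in this assay compound 2 gives "not determined" (no result reported), so it contributes no number either. Compound 1 therefore stands at the limit of the measured values (the limit of > 166000 nM in this assay, at which 1 of the 2 values shown sits), with the other entry offering nothing to compare against.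

Compound 3 `Cc1cccc(CNc2ncnc3c2ncn3[C@@H]2O[C@H](CO)[C@@H](O)[C@H]2O)c1O` is the next member to be tested. It differs from compound 1 in one place: 2-hydroxy-3-methylphenyl in place of 4-methylphenyl on a saturated chain carbon bound to a nitrogen on an aromatic ring. Within the data shown here, no step between two measured compounds is available in this set, so the size and direction of the change cannot be read from a neighbouring pair. Compound 1 sits at the limit > 166000 nM. The working expectation is therefore that compound 3 will fall at or near the same limit, with an at least 1.1-fold lower number from compound 1 to compound 3 (0.04 log units; that floor lies within the scatter) amounting to no change beyond the scatter. Compound 3 is accordingly estimated at 150000 nM, within 30000 nM to 500000 nM, and a limit rather than a number is the most probable outcome.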

Compound 3, half-maximal inhibitory concentration: 900 nM
Beside the measured number, compound 3's estimate is 170-fold (2.22 log units) above it; the whole stated range lies above it.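

Among these compounds, the change at this place is the first to give a readable result: in this assay, 2-hydroxy-3-methylphenyl in place of 4-methylphenyl on a saturated chain carbon bound to a nitrogen on an aromatic ring gives an at least 180-fold lower number from compound 1 to compound 3 (2.26 log units; beyond the scatter). This shows that the read-out responds strongly to the aryl group at this place, with the core of compound 1 otherwise unchanged, which compound 1 and compound 2 alone could not show. The step has only a lower bound, and its true size stays unknown, because one end of it is a limit and not a number: the limit of > 166000 nM in this assay, at which 1 of the 3 values shown sits.

The change adds a hydroxy group and also alters the placement of the methyl group, and the compounds shown do not separate these two parts, so the share of each in the step stays open. Also open, as far as these compounds go, is whether the step survives with an amine or a carboxylic acid in place of the hydroxy group, and compound 2, which has no reported result, offers no comparison on this.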